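Anilinoquinazoline series: aryl swap on the aromatic amine

A few compounds are considered here, and "the series" means these few. Any claim that something is new, unique, unknown or untested is made for them only; others in the source may bear on it.

Measured compounds:
compound 1, `CCS(=O)(=O)Nc1cc(-c2ccc3ncnc(Nc4ccc(F)cc4)c3c2)cnc1OC`, 6510 nM
compound 2, `CCS(=O)(=O)Nc1cc(-c2ccc3ncnc(Nc4ccc(OC)c(OC)c4)c3c2)cnc1OC`, 2430 nM
compound 3, `CCCCS(=O)(=O)Nc1cc(-c2ccc3ncnc(Nc4ccc(F)c(Cl)c4)c3c2)cnc1OC`, 65800 nM

Going by the values given here, in a functional assay on MCF7 cells (Homo sapiens) for cytotoxicity, read by sulforhodamine B assay, with a stated time of 72 h (on this read-out lower numbers stand for stronger inhibition and higher numbers for weaker inhibition), compound 2 gives the lowest number of the three; compound 1 sits above it by a 2.7-fold lower number from compound 1 to compound 2 (0.43 log units; beyond the scatter) reversed, and compound 3 lies far higher still, though compound 3 also carries a longer sulfonamide chain and a different aryl group, so no single step connects it to compound 2.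

Compound 4, `CCS(=O)(=O)Nc1cc(-c2ccc3ncnc(Nc4ccc(F)nc4)c3c2)cnc1OC`, is not yet measured. It differs from compound 2 by 6-fluoropyridin-3-yl in place of 3,4-dimethoxyphenyl on a nitrogen on an aromatic ring. Among the compounds with values here, the only single-point step available is a 2.7-fold lower number from compound 1 to compound 2 (0.43 log units; beyond the scatter), where a fluorinated aryl on that nitrogen was exchanged for 3,4-dimethoxyphenyl and the number fell modestly. Compound 4 returns to a fluorinated aryl, now with a ring nitrogen, so the expectation is that this step is roughly reversed: the number for compound 4 is expected to rise from compound 2 by about a 2.5-fold higher number from compound 2 to compound 4 (0.39 log units; beyond the scatter), landing near where compound 1 stands. Compound 4 is therefore estimated at 6000 nM in this assay, with a range from 2000 nM to 18000 nM. Within the data shown here, the spread is wide, as only one step bears on the change.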

Compound 4, half-maximal inhibitory concentration: 5390 nM
The estimate for compound 4 lay 1.1-fold (0.05 log units) above the measured number, and the stated range covers the measured number.
By their numbers in this assay, from the lowest: compound 2; then compounds 4 and 1 (each within the scatter of the next); then compound 3.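

In this assay, a 2.2-fold higher number from compound 2 to compound 4 (0.35 log units; beyond the scatter) is a second step beyond the scatter in which 3,4-dimethoxyphenyl on a nitrogen on an aromatic ring carries the lower number, now against 6-fluoropyridin-3-yl rather than 4-fluorophenyl. With a 1.2-fold lower number from compound 1 to compound 4 (0.08 log units; within the scatter), the exchange of 4-fluorophenyl for 6-fluoropyridin-3-yl stays within the scatter, so these two fluorinated aryl groups cannot be told apart at this position, and the ring nitrogen brings no readable change in this pair. Compound 2 therefore stands apart from both compound 1 and compound 4 by a modest margin, but no measurement here explains that separation.

The compounds shown leave open whether a phenyl ring with a single methoxy group, or an aryl group bearing an amine or a carboxylic acid, would read with compound 2 or with compounds 1 and 4 on this nitrogen. They also leave open how the number for compound 3, 65800 nM, divides between its butyl chain and its aryl group, as compound 3 differs from the others in two places.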